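The compounds below may be only part of what the source reports. "The series", "measured", "known", "first", "only" and "open" are said of these compounds alone.

Measured so far:
compound 1 `CNc1nc(Nc2ccc(C)c([N+](=O)[O-])c2)ncc1C(=O)Nc1cc(NC(=O)c2cccc(OC)c2)ccc1C` — 480 nM
compound 2 `CNc1nc(Nc2ccc(C)c([N+](=O)[O-])c2)ncc1C(=O)Nc1cc(NC(=O)c2cc(OC)cc(OC)c2)ccc1C` — 1070 nM
compound 3 `CNc1nc(Nc2ccc(C)c(N)c2)ncc1C(=O)Nc1cc(NC(=O)c2ccc(OC)cc2)ccc1C` — 610 nM

All three values come from a functional assay on K562 cells (Homo sapiens) for antiproliferative activity, read by CellTiter-Glo and CCK-8 assay, with a stated time of 72 h; on this read-out higher numbers stand for weaker inhibition of growth and lower numbers for stronger inhibition of growth. Compound 1 and compound 2 share a core and differ in one place: methoxy in place of hydrogen on an aromatic carbon. That change gives a 2.2-fold higher number from compound 1 to compound 2 (0.35 log units; beyond the scatter). Compound 3 carries the other core; the difference between the cores of compound 1 and compound 3 is not broken down here, and the values of compound 3 and compound 1 lie within the scatter of each other, as do those of compound 3 and compound 2.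

Compound 4, `CNc1nc(Nc2ccc(C)c(N)c2)ncc1C(=O)Nc1cc(NC(=O)c2ccc(OC)c(OC)c2)ccc1C`, is not yet measured. It differs from compound 3 in one place: methoxy in place of hydrogen on an aromatic carbon. Among the measured compounds shown here, this is the same kind of change as the one from compound 1 to compound 2, not the same: in compound 2 the entering methoxy sits meta to a methoxy group, in compound 4 it sits ortho to a methoxy group, and on the other core. For the measured compounds named here, only one earlier instance of this kind of change is available. Resting on a 2.2-fold higher number from compound 1 to compound 2 (0.35 log units; beyond the scatter), compound 4 is expected to give 1000 nM in this assay. The expected step is a 1.6-fold higher number from compound 3 to compound 4 (0.21 log units; within the scatter). The estimate is expected to lie between 400 nM and 2500 nM.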

Compound 4, concentration for 50% growth inhibition: 380 nM
Compound 4: the middle estimate sits 2.6-fold (0.42 log units) above what was measured; the measured number lies below the stated range.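

In this assay, methoxy in place of hydrogen on an aromatic carbon, here 4-methoxyphenyl to 3,4-dimethoxyphenyl, gives a 1.6-fold lower number from compound 3 to compound 4 (0.21 log units; within the scatter). Set beside the earlier instance, the change does not carry over as a constant step from one core to the other: the same change on two cores in this assay, a 2.2-fold higher number (0.35 log units; beyond the scatter) from compound 1 to compound 2 and a 1.6-fold lower number (0.21 log units; within the scatter) from compound 3 to compound 4, 3.6-fold (0.55 log units) apart, beyond the scatter of two such steps

This does not show that the core alone separates the two steps: the pairs also differ in the place of the entering methoxy, ortho to a methoxy group in compound 4 and meta to a methoxy group in compound 2, and two pairs cannot tell core and place apart.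

Open, on these data alone, is what the 4-methoxyphenyl and 3,4-dimethoxyphenyl groups give on the core of compound 1, which would set the core against the place of the methoxy. Also open, as far as these compounds go, is how a hydroxyl group, a fluorine atom or an amine would compare with methoxy at the same ring position.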